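Benzyl to 2-methylphenyl on selenium: working notes

The compounds below may be only part of what the source reports. "The series", "measured", "known", "first", "only" and "open" are said of these compounds alone.

Within the data shown here, in a functional assay on SK-MEL-147 cells (Homo sapiens) for cytotoxicity, read by MTT assay, with a stated time of 24 h (on this read-out higher numbers stand for an effect only at larger amounts of compound and lower numbers for an effect already at smaller amounts), compound 1 (`CCOC(=O)c1cc([Se]Cc2ccccc2)c2cc(OC)ccc2n1`) gives 40700 nM, the lower of the two numbers so far. Compound 2 (`CCOC(=O)c1cc([Se]Cc2ccccc2)c2cc(Cl)ccc2n1`) gives 84500 nM. Among the measured compounds shown here, the one measured step, a 2.1-fold higher number from compound 1 to compound 2 (0.32 log units; beyond the scatter), is modest and swaps chloro for methoxy on an aromatic carbon.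

Compound 3 (`CCOC(=O)c1cc([Se]c2ccccc2C)c2cc(OC)ccc2n1`) keeps the core of compound 1 and carries 2-methylphenyl in place of benzyl on a selenium. For the measured compounds named here, no measured step touches this place, so the data give no direction for the change. The modest step above offers only a rough guide to size, at a different place in the structure. In this assay no clear shift beyond the scatter is expected, and the range is kept wide. The expected step is a 1.2-fold higher number from compound 1 to compound 3 (0.09 log units; within the scatter). Compound 3 is estimated at 50000 nM, with an expected range of 18000 nM to 130000 nM.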

Compound 3, half-maximal effective concentration: 38900 nM
Estimate against measurement, compound 3: 1.3-fold (0.11 log units) above; the range from low to high includes it.
By their numbers in this assay, from the lowest: compounds 3 and 1 (each within the scatter of the next); then compound 2.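

On a selenium whose other neighbour is an aromatic carbon, the first step read at this place is a 1.0-fold lower number from compound 1 to compound 3 (0.02 log units; within the scatter) in this assay, so 2-methylphenyl and benzyl cannot be told apart here. With the core of compound 1 held constant, the change keeps one six-membered aromatic ring of carbon only on the selenium, and this exchange leaves the number within the scatter, unlike the chloro for methoxy step on an aromatic carbon, which is a 2.1-fold higher number from compound 1 to compound 2 (0.32 log units; beyond the scatter) and lies beyond it. Nothing measured here explains why the two groups read alike.

The compounds shown leave open whether this equivalence holds on the core of compound 2, which carries chloro. They also leave open how an amine or a carboxylic acid on a longer chain at the selenium would read.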